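The compounds below may be only part of what the source reports. "The series", "measured", "known", "first", "only" and "open" are said of these compounds alone.

Compound 1 `Nc1ncnc2c1ncn2C[C@@H]1C[C@H](CO)c2ccccc21`: 24 ug/mL
Compound 2 `OC[C@H]1C[C@@H](Cn2cnc3c(O)ncnc32)c2ccccc21`: 24 ug/mL

For the measured compounds named here, both compounds were tested in a functional assay on MOLT-4 cells (Homo sapiens) (a higher number here means a weaker inhibitor, a lower number a stronger inhibitor), and the two stand level, so compound 2 offers no gain or loss against its only measured neighbour. The next compound, compound 3 `OC[C@H]1C[C@@H](Cn2cnc3c(-c4ccc(Cl)cc4)ncnc32)c2ccccc21`, is changed at the same spot on the shared core. The change is 4-chlorophenyl in place of hydroxy on an aromatic carbon, a whole ring where there was a single small group.

Going by the values given here, only one measured step bears on this. It is no change at the digits printed from compound 1 to compound 2 (within the scatter), and it put hydroxy in place of amino on that same carbon. That swap shows that exchanging one small group for another at this spot left this assay unmoved. Among the compounds with values here, it says little about a group as large as 4-chlorophenyl, and no measured compound carries a ring there. A modest move toward stronger inhibition is a tentative expectation, and a result level with compound 2 would be no surprise. The expected size is a 2.0-fold lower number from compound 2 to compound 3 (0.30 log units; within the scatter). Compound 3 is estimated at 12 ug/mL, with an expected range from 4 ug/mL to 35 ug/mL.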

Compound 3, half-maximal inhibitory concentration: 0.63 ug/mL
Beside the measured number, compound 3's estimate is 19-fold (1.28 log units) above it; measured number below the stated range.
By their numbers in this assay, from the lowest: compound 3; then compounds 1 and 2 (each within the scatter of the next).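

In this assay, this aromatic carbon looked indifferent while only single small groups were exchanged there (no change at the digits printed from compound 1 to compound 2 (within the scatter)), but that flat result does not extend to larger groups. With 4-chlorophenyl in place of hydroxy, the step is large (a 38-fold lower number from compound 2 to compound 3 (1.58 log units; beyond the scatter)), and the step is equally large with 4-chlorophenyl in place of amino (a 38-fold lower number from compound 1 to compound 3 (1.58 log units; beyond the scatter)), so compound 3 is a clearly stronger inhibitor than either earlier compound. No measurement in hand accounts for this jump, so it stands as an observed effect without an explanation.

The 4-chlorophenyl group brings in a six-membered ring and a chlorine together, so the compounds shown cannot say how much of the change belongs to the ring and how much to the chlorine; an unsubstituted phenyl or a 4-methoxyphenyl at this carbon would help to separate the two. From the compounds shown here alone, it also remains open whether a ring is needed at all, or whether a non-aromatic group such as a piperidine or a longer alkyl chain would lower the number in the same way.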